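Chlorinated Furan-2-yl Enters Where Furan-3-yl Stood

The source may hold more compounds than are shown below. What is called first, only, known or untested is meant among the compounds shown, and "the series" means these compounds.

Compound 1 `Cc1ccsc1-c1cc(-c2ccoc2)cc(-c2ccco2)n1`: 5.4%
Compound 2 `Cc1ccsc1-c1cc(-c2ccoc2)cc(-c2ccc(Cl)cc2)n1`: 85.9%

Of the compounds shown here, two built on one shared core have been measured in an assay on isolated protein for inhibition of DNA topoisomerase 1 (Homo sapiens), with a stated time of 30 min, tested at 100 uM; on this read-out higher numbers stand for more inhibition at the one concentration tested (going by the name of the read-out) and lower numbers for less inhibition. Among the compounds with values here, compound 1 gives 5.4%, while compound 2 gives 85.9%, the higher of the two numbers, and the single measured step of a number 80.5 percentage points higher from compound 1 to compound 2 (beyond the scatter) separates them. Compound 3 `Cc1ccsc1-c1cc(-c2ccc(Cl)o2)cc(-c2ccc(Cl)cc2)n1` has not been measured yet. It differs from compound 2 in one place: 5-chlorofuran-2-yl in place of furan-3-yl on an aromatic carbon. Within the data shown here, no measured step touches this position. Among the measured compounds shown here, the one available step, a number 80.5 percentage points higher from compound 1 to compound 2 (beyond the scatter), concerns a different ring on the core and offers no direct guide; it shows only that exchanging one aryl group on this core can move the read-out far. The 4-chlorophenyl group of compound 2 stays in place in compound 3, so compound 3 is expected to stay within reach of compound 2, the expected step being a number 7.9 percentage points lower from compound 2 to compound 3 (within the scatter). Compound 3 is therefore estimated at 78%, within a range from 45% to 98%.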

Compound 3, a percentage reported as inhibition, at one concentration (the size of the read-out at that concentration, not a potency): 5.1%
Estimate against measurement, compound 3: 72.9 percentage points above; measured number below the stated range.
By their numbers in this assay, from the lowest: compounds 3 and 1 (each within the scatter of the next); then compound 2.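

In this assay, the carbon opposite the ring nitrogen turns out to matter as much as the place where the earlier step was seen: a number 80.8 percentage points lower from compound 2 to compound 3 (beyond the scatter), with 5-chlorofuran-2-yl in place of furan-3-yl. Keeping the 4-chlorophenyl group is therefore not enough to hold the read-out, since compound 3 carries that group and gives 5.1%. Nothing available bears on why the number falls so far.

The change joins two differences, a furan attached through another ring carbon and an added chlorine, and the compounds shown do not separate them. Which of the two accounts for the drop stays open, as does how an unsubstituted furan-2-yl, an amine or a carboxylic acid on this carbon would read.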